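The compounds below may be only part of what the source reports. "The series", "measured", "known", "first", "only" and "open" are said of these compounds alone.

Compound 2 `Cc1nnc(-c2cccc(-c3ccc(C(=O)N(Cc4cccc(OCCCCCC(=O)O)c4)C(C)C)cc3)c2)o1` stands at the assay limit in an ADME assay on HepG2 cells (Homo sapiens) for cytotoxicity, read by CellTiter-Glo and resazurin assay, with a stated time of 72 h (on this read-out higher numbers stand for an effect only at larger amounts of compound and lower numbers for an effect already at smaller amounts), where compound 2 gives > 26000 nM. Compound 1 `CC(C)N(Cc1cccc(OCCCCCC(=O)O)c1)C(=O)c1ccc(-c2cccc(-c3ccccc3)c2)cc1` also shows only a limit; in this assay compound 1 gives > 26000 nM. Within the data shown here, the single measured step, a step that the two limits leave unreadable from compound 1 to compound 2, therefore has no readable size, since both values rest at the limit of > 26000 nM in this assay, at which 2 of the 2 values shown sit. Compound 3 `CC(C)N(Cc1cccc(OCCCCCC(=O)O)c1)C(=O)c1ccc(-c2cccc(Br)c2)cc1` carries the change (bromo in place of 5-methyl-1,3,4-oxadiazol-2-yl on an aromatic carbon). Among the measured compounds shown here, no measured step with a readable size bears on this change, so compound 3 is expected to remain at the limit, with a step that the limit leaves unreadable from compound 2 to compound 3 estimated as no step beyond the scatter. Compound 3 is accordingly estimated at 30000 nM, between 15000 nM and 60000 nM.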

Compound 3, half-maximal effective concentration: > 26000 nM
Compound 3: no number, only a limit (the forecaster's own chance of this, stated with the estimate: 85%); the middle value lies beyond the limit too.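

No step can be read among compound 1, compound 2 and compound 3 in this assay, because each gives only a limit: the limit of > 26000 nM in this assay, at which 3 of the 3 values shown sit.

The compounds shown leave open how the phenyl, 5-methyl-1,3,4-oxadiazol-2-yl and bromo compounds truly rank in this read-out.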